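Ring stereocentres in the series: compound 2 to compound 3

The source may report more compounds than this note shows. Statements on the series, on what has been measured and on what is new or still open speak of the compounds shown alone.

For the measured compounds named here, in an ADME assay on liver (Mus musculus, strain C57BL/6) for metabolic stability, read by HPLC, with a stated time of 12 h (a lower number here means that the compound disappears faster, a higher number that the compound lasts longer), compound 2 (`O=C(O)[C@H](CO)NC(=O)[C@@H]1C[C@H](O)CN1`) gives 0.51 h, the only actual number so far. Compound 1 (`O=C(O)[C@H](CO)NC(=O)[C@H]1C[C@@H](O)CN1`) gives > 12 h, which is a limit of the assay and not a number. Going by the values given here, the single measured step, an at least 23-fold lower number from compound 1 to compound 2 (1.37 log units; beyond the scatter), is large and beyond the scatter. Its size rests on (the limit of > 12 h in this assay, at which 1 of the 2 values shown sits), and the structural change behind it is confined to the fact that compounds 1 and 2 differ only in the configuration as drawn.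

Compound 3 (`O=C(O)[C@H](CO)NC(=O)[C@@H]1C[C@@H](O)CN1`) follows from compound 2 by one change: the two compounds have the same atoms and bonds and differ only in configuration as drawn: 1 of 3 stereo elements differ; a stereocentre at a saturated ring carbon is drawn S in compound 2 and R in compound 3. Compound 3 therefore has one ring stereocentre as drawn in compound 1 and the other as drawn in compound 2. The data do not show how an at least 23-fold lower number from compound 1 to compound 2 (1.37 log units; beyond the scatter) divides between the two centres. Among the compounds with values here, only one centre changes here, so a smaller step in the opposite direction is expected in this assay, though a step within the scatter cannot be excluded. The estimated step is a 1.8-fold higher number from compound 2 to compound 3 (0.25 log units; within the scatter). For compound 3 the estimated half-life is 0.9 h, with an expected range of 0.25 h to 5 h.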

Compound 3, half-life: 0.27 h
Beside the measured number, compound 3's estimate is 3.3-fold (0.52 log units) above it; low and high end bracket the measured number.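

In this assay, inverting one ring stereocentre in the short-lived compounds reads as a 1.9-fold lower number from compound 2 to compound 3 (0.28 log units; within the scatter), so this centre alone makes no clear difference here. The other ring stereocentre reads as an at least 44-fold lower number from compound 1 to compound 3 (1.64 log units; beyond the scatter), a large step beyond the scatter, and the large loss of half-life can now be placed at a single centre, with nothing else in the structure changing: the fact that compounds 1 and 3 differ only in the configuration as drawn Compound 1 gives > 12 h, which is a limit of the assay and not a number.

The compounds shown do not tell whether the centre with the small step would also have little effect with the other centre held as drawn in compound 1, nor what process shortens the half-life in compound 2 and compound 3. They also leave open whether the large difference at the second centre would persist with a methyl ether in place of the ring hydroxyl or a methyl ester in place of the carboxylic acid.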